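Working notes: tolerance of compounds 1 to 3 in J774 cells

The source may hold more compounds than are shown below. What is called first, only, known or untested is meant among the compounds shown, and "the series" means these compounds.

Measured so far:
compound 1, `CC(/C=N/N(C)c1ccc([N+](=O)[O-])cc1)=N\NC(=O)c1ccc(N)cc1`, 51700 nM
compound 2, `CC(/C=N/Nc1ccc([N+](=O)[O-])cc1)=N\NC(=O)c1ccc([N+](=O)[O-])cc1`, > 100000 nM

In an ADME assay on J774 cells (Mus musculus, strain BALB/c) for cytotoxicity, read by resazurin assay, with a stated time of 72 h (a higher number here means that more compound is tolerated, a lower number that less compound is tolerated), compound 1 gives 51700 nM. For compound 2 only a limit is known: in this assay compound 2 reads > 100000 nM, which is a limit of the assay and not a number. As far as these compounds go, compound 2 thus sits at the limit of > 100000 nM in this assay, at which 1 of the 2 values shown sits, the upper edge of what the two values shown can tell, and how far beyond it the true value lies stays open.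

Compound 3, `CC(/C=N/Nc1ccc([N+](=O)[O-])cc1)=N\NC(=O)c1ccc(Cl)cc1`, has not yet been measured. It differs from compound 2 in one place: chloro in place of nitro on an aromatic carbon. For the measured compounds named here, no step between measured compounds matches this change, so no size can be read off for it. Going by the values given here, with compound 2 already at the limit and no comparable step to lean on, the expectation for compound 3 is a step from compound 2 of an at least 1.2-fold lower number from compound 2 to compound 3 (0.09 log units; that floor lies within the scatter), not clearly beyond the scatter. Compound 3 is expected to give 80000 nM in this assay, within a range of 30000 nM to 200000 nM.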

Compound 3, half-maximal cytotoxic concentration: 63900 nM
Compound 3: the middle estimate sits 1.3-fold (0.10 log units) above what was measured, and the stated range covers the measured number.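

With chloro on this aromatic carbon, para to a large group, the series now has a real number at this place: in this assay compound 3 gives 63900 nM. For the compounds shown here, the change from 4-nitrophenyl to 4-chlorophenyl can thus be given a size for the first time, though only as a floor: an at least 1.5-fold lower number from compound 2 to compound 3 (0.19 log units; that floor lies within the scatter). The true size of the step stays unknown because compound 2 carries a limit of the assay and not a number: the limit of > 100000 nM in this assay, at which 1 of the 3 values shown sits.

Whether the step in fact goes beyond the scatter cannot be told from these compounds. Going by these compounds alone, how a carboxylic acid, a methoxy group or a longer chain at this same place would read in this assay also stays open, since chloro and nitro are the only two groups compared here.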